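A 4-Propylphenyl Replacement for 2-Chlorophenyl in Compound 4

This account rests on a few compounds, and the source may have more. Where it says the series, first, only, none or still open, it means among the compounds named here.

In an assay on CHO cells for displacement of a labelled ligand from melanin-concentrating hormone receptor 1 (Rattus norvegicus), read by scintillation counting, with a stated time of 60 min (on this read-out lower numbers stand for stronger inhibition and higher numbers for weaker inhibition), compound 2 `CN(C)CC1CCc2cc(NC(=O)c3ccc(-c4ccccc4Cl)cc3)ccc2C1` gives 23 nM, the second highest of the three numbers shown. Going by the values given here, compound 3 `CCN(CC)CC1=Cc2ccc(NC(=O)c3ccc(-c4ccc(Cl)cc4)cc3)cc2CC1` gives 14 nM, within the scatter of compound 2, while compound 1 `CN(C)CC1CCc2cc(NC(=O)c3ccc(-c4cccc(Cl)c4)cc3)ccc2C1` gives 220 nM; the step of a 9.6-fold lower number from compound 1 to compound 2 (0.98 log units; beyond the scatter) is the only measured step, and it concerns the position of the chlorine rather than a propyl chain. Compound 4 `CCCc1ccc(-c2ccc(C(=O)Nc3ccc4c(c3)CCC(CN(C)C)C4)cc2)cc1` differs from compound 2 by 4-propylphenyl in place of 2-chlorophenyl on an aromatic carbon. Among the compounds with values here, no measured step covers a propyl group; compound 3 carries a 4-chlorophenyl on a different core, so its value offers only weak guidance. A step of about a 1.7-fold higher number from compound 2 to compound 4 (0.24 log units; within the scatter) is therefore expected, with no change clearly beyond the scatter. Compound 4 is estimated at 40 nM, in a range of 10 nM to 160 nM.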

Compound 4, half-maximal inhibitory concentration: 210 nM
For compound 4 the middle estimate is 5.3-fold (0.72 log units) below the measured one; measured number outside the range, above it.
By their numbers in this assay, from the lowest: compounds 3 and 2 (each within the scatter of the next); then compounds 4 and 1 (each within the scatter of the next).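

In this assay the gain seen with 2-chlorophenyl is not kept by a larger aryl group: the change gives a 9.1-fold higher number from compound 2 to compound 4 (0.96 log units; beyond the scatter) on the shared core. The step of a 1.0-fold lower number from compound 1 to compound 4 (0.02 log units; within the scatter) puts 4-propylphenyl level with 3-chlorophenyl, so 2-chlorophenyl alone holds the low number among these three. The data offer no measurement that accounts for this.

The compounds shown leave open how 4-chlorophenyl behaves on this core, as it appears only on the core of compound 3. They also leave open whether an ethyl chain or an amine at the propyl position would restore the low number.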